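The compounds below may be only part of what the source reports. "The series", "measured", "known", "first", "only" and "open" are said of these compounds alone.

Compound 1 `N#Cc1cccc(-c2nc(N)c3cc(CN4CCC(F)CC4)sc3n2)c1` and compound 2 `Nc1nc(-c2cccc([N+](=O)[O-])c2)nc2sc(CN3CCC(F)CC3)cc12` share a core and differ only in the group on the six-membered carbon ring. In an assay on CHO-K1 cells for antagonist activity at adenosine receptor A1 (Homo sapiens), read by a beta-galactosidase reporter, with stated times of 15 min and 6 h (a higher number here means a weaker inhibitor, a lower number a stronger inhibitor), compound 1 gives 2950 nM. Compound 2 gives > 10000 nM in this assay, which is a limit of the assay rather than a number, so compound 2 stands at the weak end of what can be read; this is the case described by the limit of > 10000 nM in this assay, at which 1 of the 2 values shown sits. The step of an at least 3.3-fold higher number from compound 1 to compound 2 (0.53 log units; beyond the scatter) is thus known only as a lower bound. Compound 3 `CN(C)C(=O)c1cccc(-c2nc(N)c3cc(CN4CCC(F)CC4)sc3n2)c1` is not yet measured in this assay. It differs from compound 2 by dimethylcarbamoyl in place of nitro on an aromatic carbon. Going by the values given here, only the step from compound 1 to compound 2 bears on this, and it shows nitro weaker than cyano; the dimethylcarbamoyl group was not part of any measured pair. Compound 3 is therefore expected to remain a weak inhibitor, at 8000 nM, between 2000 nM and 30000 nM, a step of an at least 1.2-fold lower number from compound 2 to compound 3 (0.09 log units; that floor lies within the scatter) being the estimate.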

Compound 3, inhibition constant: > 10000 nM
Compound 3: only a limit was reported; the forecaster's own chance of this, stated with the estimate: 40%; middle value at least 1.2-fold (0.09 log units) from the limit.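

With dimethylcarbamoyl in place of cyano on this aromatic carbon, the data show an at least 3.3-fold higher number from compound 1 to compound 3 (0.53 log units; beyond the scatter), so nitro is no longer the only replacement of cyano here that raises the number. Compound 3 gives > 10000 nM in this assay, which is a limit of the assay, so the step between compound 2 and compound 3 cannot be read and the two groups cannot be ranked against each other. Cyano therefore remains the only group at this place with a readable number, and the series now sits mostly at the edge of what can be read: the limit of > 10000 nM in this assay, at which 2 of the 3 values shown sit.

As far as these compounds go, how weak compound 2 and compound 3 really are stays open. Also open, from the compounds shown here alone, is whether an amine, a carboxylic acid or a methoxy group at this place would give a readable number, and on which side of compound 1 it would fall.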